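Cyclohexyl in Place of Phenylethyl on the Urea Nitrogen

The source may hold more compounds than are shown below. What is called first, only, known or untested is meant among the compounds shown, and "the series" means these compounds.

Compound 1 `Cc1nc(N)sc1CCCN/C(N)=N/C(=O)N[C@@H](C)c1ccccc1` gives 0.46 in a functional assay on HEK293T cells for agonist activity at histamine H2 receptor (Homo sapiens), read by beta-arrestin recruitment (a lower number here means a smaller maximal response, a higher number a larger maximal response), the higher of the two numbers recorded. Compound 2 `Cc1nc(N)sc1CCCN/C(N)=N/C(=S)N[C@H](C)c1ccccc1` gives 0.11 in this assay, a value beyond the scatter below compound 1. Compound 3 `Cc1nc(N)sc1CCCN/C(N)=N/C(=O)NC1CCCCC1` differs from compound 1 by cyclohexyl in place of 1-phenylethyl on an amide-type nitrogen. No change of this kind occurs among the measured pair, so the outcome rests on expectation alone. A small move downward, or none beyond the scatter, is expected for a number 0.060 lower from compound 1 to compound 3 (within the scatter). Compound 3 is therefore estimated to reach an intrinsic activity of about 0.4 in this assay, with a range from 0.15 to 0.65.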

Compound 3, intrinsic activity: the largest response reached, as a fraction of the reference agonist's: 0.43
The estimate for compound 3 lay 0.030 below the measured number, and the stated range covers the measured number.
By their numbers in this assay, from the lowest: compound 2; then compounds 3 and 1 (each within the scatter of the next).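

The step in this assay for cyclohexyl in place of 1-phenylethyl on an amide-type nitrogen is a number 0.030 lower from compound 1 to compound 3 (within the scatter), so in this pair the maximal response at this position does not depend on keeping the aromatic ring or the defined stereocentre of 1-phenylethyl. Going by these compounds alone, the step is the first at this position, and nothing available explains it.

Still open, from the compounds shown here alone, is whether a smaller cyclopentyl ring, an open n-butyl chain or a benzyl group on this nitrogen would give a similar response. Going by these compounds, a piperidin-4-yl ring, which adds a ring amine, also remains open.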